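A few compounds are considered here, and "the series" means these few. Any claim that something is new, unique, unknown or untested is made for them only; others in the source may bear on it.

Compound 1 `N#CC1=C(N)OC(c2c[nH]c3ccccc23)=C(C#N)C1c1ccccc1Cl` is measured in a functional assay, tested at 200 ug/mL (on this read-out higher numbers stand for a stronger effect at the one concentration tested and lower numbers for a weaker effect), where compound 1 gives 14.5%. Among the two numbers recorded, compound 1 stands highest; the nearest is compound 3 `N#CC1=C(N)OC(c2c[nH]c3ccccc23)=C(C#N)C1c1ccc(Br)cc1`, which gives 10.6%, and the step of a number 3.9 percentage points lower from compound 1 to compound 3 (within the scatter) lies within the scatter. Compound 2 `N#CC1=C(N)OC(c2c[nH]c3ccccc23)=C(C#N)C1c1ccc2ccccc2c1` is recorded as "not active" (no number reported) without a number. Compound 4 `COc1ccc(C2C(C#N)=C(N)OC(c3c[nH]c4ccccc34)=C2C#N)cc1` differs from compound 1 in one place: 4-methoxyphenyl in place of 2-chlorophenyl on a saturated ring carbon. Among the compounds with values here, the only measured step that bears on this change is the exchange of one aryl group for another, a number 3.9 percentage points lower from compound 1 to compound 3 (within the scatter), which stayed within the scatter, while compound 2 shows that such an exchange can also leave no number at all. One therefore expects no step beyond the scatter, a number 2.5 percentage points lower from compound 1 to compound 4 (within the scatter), and estimates compound 4 at 12%, between 3% and 22%.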

Compound 4, a percentage reported as activity, at one concentration (the size of the read-out at that concentration, not a potency): 26.4%
Compound 4: the middle estimate sits 14.4 percentage points below what was measured, outside the stated range (above it).
By their numbers in this assay, from the lowest: compounds 3 and 1 (each within the scatter of the next); then compound 4.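

The aryl group on the saturated ring carbon can shift the read-out in this assay beyond the scatter: 4-methoxyphenyl in place of 2-chlorophenyl gives a number 11.9 percentage points higher from compound 1 to compound 4 (beyond the scatter). Methoxy in place of bromo on an aromatic carbon gives a number 15.8 percentage points higher from compound 3 to compound 4 (beyond the scatter), showing that the substituent on the phenyl ring can matter even when the ring itself is kept. Nothing available explains either step. From the compounds shown here alone, it remains open whether an amine or a hydroxy group in place of the methoxy would give a similar read-out, and whether 2-methoxyphenyl would match 4-methoxyphenyl.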